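Working notes: aryl change from compound 2 to compound 3

The compounds below may be only part of what the source reports. "The series", "measured", "known", "first", "only" and "open" are said of these compounds alone.

Compound 1 `O=C(/C=C/c1ccccc1)Nc1cc2c(Nc3ccc(Cl)c(Cl)c3)ncnc2s1`: 7600 nM
Compound 2 `C#Cc1cccc(Nc2ncnc3sc(NC(=O)/C=C/c4ccccc4)cc23)c1`: 10100 nM

In a functional assay on A549 cells (Homo sapiens) for antiproliferative activity, read by MTT assay, with a stated time of 48 h (on this read-out higher numbers stand for weaker inhibition and lower numbers for stronger inhibition), compound 2 gives 10100 nM, which lies within the scatter of compound 1 at 7600 nM. Compound 3 `O=C(/C=C/c1ccccc1)Nc1cc2c(Nc3cc(Cl)cc(Cl)c3)ncnc2s1` is the next to be read, with this difference from compound 2: 3,5-dichlorophenyl in place of 3-ethynylphenyl on a nitrogen on an aromatic ring. For the measured compounds named here, one measured step bears on it: a 1.3-fold higher number from compound 1 to compound 2 (0.12 log units; within the scatter), which exchanged 3,4-dichlorophenyl for 3-ethynylphenyl at the same place. Going by the values given here, no measured compound carries 3,5-dichlorophenyl, so no step beyond the scatter is expected. The expected step is a 1.3-fold lower number from compound 2 to compound 3 (0.10 log units; within the scatter). Compound 3 is estimated at 8000 nM, with an expected range of 4000 nM to 16000 nM.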

Compound 3, half-maximal inhibitory concentration: 40 nM
The estimate for compound 3 lay 200-fold (2.30 log units) above the measured number; measured number outside the range, below it.
By their numbers in this assay, from the lowest: compound 3; then compounds 1 and 2 (each within the scatter of the next).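

At this place, on a nitrogen on an aromatic ring, the aryl group matters far more than the first pair suggested: in this assay, 3,5-dichlorophenyl gives a 250-fold lower number from compound 2 to compound 3 (2.40 log units; beyond the scatter). The two dichlorophenyl groups also part sharply, with a 190-fold lower number from compound 1 to compound 3 (2.28 log units; beyond the scatter), so the same two chlorines give very different numbers depending on where they stand on the ring. No measured data bear on the reason for this difference. From the compounds shown here alone, whether methoxy or fluorine in place of the chlorines would hold the low number stays open, as does whether one chlorine would suffice.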